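Predicting Cytotoxicity of Compound 4 from Three Limit Values

A few compounds are considered here, and "the series" means these few. Any claim that something is new, unique, unknown or untested is made for them only; others in the source may bear on it.

Measured so far in an ADME assay on HFF cells (Homo sapiens) for cytotoxicity, with a stated time of 8 days; on this read-out lower numbers stand for higher toxicity in this test and higher numbers for lower toxicity in this test:
Compound 1 `CC(C)CSc1nc(N)nc2c1ncn2/C=C1/CC1(CO)CO` gives > 300000 nM, which is a limit of the assay rather than a number.
Compound 2 `CCCSc1nc(N)nc2c1ncn2/C=C1/CC1(CO)CO` gives > 300000 nM, also a limit.
Compound 3 `Nc1nc(OCC(F)(F)F)c2ncn(/C=C3/CC3(CO)CO)c2n1` gives > 300000 nM, again a limit.

Compound 1 therefore stands at the limit of this assay, and so do the two other compounds, as the limit of > 300000 nM in this assay, at which 3 of the 3 values shown sit, sums up. Among the compounds with values here, with every value a limit, the steps a step that the two limits leave unreadable from compound 1 to compound 2, a step that the two limits leave unreadable from compound 1 to compound 3 and a step that the two limits leave unreadable from compound 2 to compound 3 cannot be given a size; they show only that no compound measured so far reached a readable number in this test.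

Compound 4 `CCCCCCOc1nc(N)nc2c1ncn2/C=C1/CC1(CO)CO` has not yet been measured. It differs from compound 1 in one place: hexyloxy in place of isobutylsulfanyl on an aromatic carbon. The measured steps that bear on this change are those replacing the isobutylsulfanyl or propylsulfanyl group on the same aromatic carbon, and none of them produced a readable value. The expectation for compound 4 is therefore no step beyond the scatter, a number no higher from compound 1 to compound 4 (the limit leaves the size open), and most likely another limit. The estimate for compound 4 is 300000 nM, with a range from 120000 nM to 300000 nM.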

Compound 4, half-maximal cytotoxic concentration: > 200000 nM
Compound 4 ended at the assay's limit; the forecaster's own chance of this, stated with the estimate: 85%; the middle value is on the limit's open side.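

In this assay compound 4 gives > 200000 nM, which is a limit and not a number. Within the data shown here, compound 1, compound 2 and compound 3 also stand at limits, so no step to compound 4 can be read. The compounds shown leave open what concentration of any of them would reach a readable cytotoxic value.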